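Ethoxycarbonyl on the aryl ether oxygen: expected cytotoxicity

The source may report more compounds than this note shows. Statements on the series, on what has been measured and on what is new or still open speak of the compounds shown alone.

Measured compounds:
Compound 1 `COc1ccc(C2=C(c3cc(OC)c(OC)c(OC)c3)C(=O)CC2C)cc1C(=O)O` gives a limit, > 100 ug/mL, in an ADME assay on HEp-2 cells (Homo sapiens) for cytotoxicity, read by MTT assay, with a stated time of 72 h; on this read-out higher numbers stand for weaker inhibition and lower numbers for stronger inhibition.
Compound 2 `COc1ccc(C2=C(c3cc(OC)c(OC)c(OC)c3)C(=O)C(OC(C)=O)C2)cc1OC(C)C` gives a limit, > 100 ug/mL, in this assay.
Compound 3 `COc1ccc(C2=C(c3cc(OC)c(OC)c(OC)c3)C(=O)CC2O)cc1` gives a limit, > 100 ug/mL, in this assay.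

Compound 3 therefore does not stand at a number at all but at a limit of this assay. Among the measured compounds shown here, the same holds for the other two compounds, as the limit of > 100 ug/mL in this assay, at which 3 of the 3 values shown sit, records, so no step between measured compounds can be read from these numbers and no order among them can be given.

Compound 4 `CCOC(=O)COc1ccc(C2=C(c3cc(OC)c(OC)c(OC)c3)C(=O)CC2O)cc1` is not yet measured. It differs from compound 3 in one place: ethoxycarbonyl in place of hydrogen on a saturated chain carbon bound to an oxygen on an aromatic ring. For the measured compounds named here, with every measured value sitting at a limit, there is nothing to show how this kind of change moves the read-out, and no step of any size, in either direction, can be counted on. The expectation is that compound 4 also lands where compound 3 does, so the estimated step that the limit leaves unreadable from compound 3 to compound 4 is none beyond the scatter. Compound 4 is expected to give about 150 ug/mL, within a range from 60 ug/mL to 400 ug/mL, most likely reported again as a limit.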

Compound 4, half-maximal inhibitory concentration: > 100 ug/mL
Compound 4: only a limit was reported; the forecaster's own chance of this, stated with the estimate: 85%; the middle value lies beyond the limit too.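

No step can be read from compound 3 to compound 4, because both results in this assay are limits and not numbers: the limit of > 100 ug/mL in this assay, at which 4 of the 4 values shown sit.

The compounds shown leave open how strongly any of them inhibits these cells, and whether ethoxycarbonyl in place of hydrogen on a saturated chain carbon bound to an oxygen on an aromatic ring changes that at all.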